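From compound 1 to compound 3: a side-chain exchange

The source may hold more compounds than are shown below. What is called first, only, known or untested is meant among the compounds shown, and "the series" means these compounds.

In a physicochemical assay for lipophilicity, read by HPLC, at pH 7.4 (on this read-out lower numbers stand for lower lipophilicity and higher numbers for higher lipophilicity), compound 1 (`COCCOc1cc2oc(=O)n(CCC(=O)O)c2cc1Cl`) gives 0.88 as the lower of the two numbers in hand. Compound 2 (`C[C@@H](Oc1cc2oc(=O)n(CCC(=O)O)c2cc1Cl)c1ccc(F)cn1`) gives 1.98 and stands higher by more than the usual scatter. Among the measured compounds shown here, compound 3 (`O=C(O)CCn1c(=O)oc2cc(OCC3CCC3)c(Cl)cc21`) has no measurement yet. It carries cyclobutyl in place of methoxymethyl on a saturated chain carbon bound to an oxygen on an aromatic ring. For the measured compounds named here, no measured step covers this change, so the expectation rests on the structural change alone. An upward step beyond the scatter is expected in this assay and estimated as a number 1.02 log units higher from compound 1 to compound 3 (beyond the scatter) for this exchange. Compound 3 is expected at 1.9 with an estimated range from 1.5 to 2.3 in this read-out.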

Compound 3, distribution coefficient: 2.9
Beside the measured number, compound 3's estimate is 1.00 log units below it, and the stated range ends below it.
By their numbers in this assay, from the lowest: compound 1; then compound 2; then compound 3.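

In this assay, among the compounds shown here, cyclobutyl in place of methoxymethyl on a saturated chain carbon bound to an oxygen on an aromatic ring gives a number 2.02 log units higher from compound 1 to compound 3 (beyond the scatter), the first measured step at this place. The exchange replaces an open group holding one hydrogen-bond acceptor with a four-membered carbon ring holding none, while the rest of compound 1 stays unchanged. Nothing at hand accounts for the size of this step. Still open, as far as these compounds go, is whether the ring or the missing oxygen carries the step. An oxetanyl ring or an open propyl chain at this place would separate the two.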